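Fluoro in Place of Methoxy on Two Related Cores

This account rests on a few compounds, and the source may have more. Where it says the series, first, only, none or still open, it means among the compounds named here.

The measured compounds:
compound 1 `CCN1CCN(c2nc(NCc3ccc(F)cc3)nc3c2ncn3CCCN2CCCC2)CC1`, which in an assay on HEK293 cells for antagonist activity at Toll-like receptor 9 (Homo sapiens), read by spectrophotometry (on this read-out higher numbers stand for weaker inhibition and lower numbers for stronger inhibition), gives 40 nM;
compound 3 `CCN1CCN(c2nc(NCc3ccc(OC)cc3)nc3c2ncn3CCCN2CCCC2)CC1`, which in this assay gives 80 nM;
compound 2 `CCN1CCN(CCCn2cnc3c(N4CCN(C(=O)C5CCCC5)CC4)nc(NCc4ccc(OC)cc4)nc32)CC1`, for which this assay reports only the limit > 30000 nM rather than a number.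

Compound 3 and compound 1 share a core and differ by one change, (fluoro in place of methoxy on an aromatic carbon). That change gave a 2.0-fold lower number from compound 3 to compound 1 (0.30 log units; within the scatter), so the two values tell no difference in potency.

Compound 2 stands on a different core; the difference between the two cores is not broken down here. What is known of compound 2 is only that it sits at the limit, as shown by the limit of > 30000 nM in this assay, at which 1 of the 3 values shown sits.

Compound 4 `CCN1CCN(CCCn2cnc3c(N4CCN(C(=O)C5CCCC5)CC4)nc(NCc4ccc(F)cc4)nc32)CC1` is not yet measured. It is made from compound 2 by the same change, (fluoro in place of methoxy on an aromatic carbon), with the place described in the same words as for the pair compound 3 to compound 1. Because that step gave a 2.0-fold lower number from compound 3 to compound 1 (0.30 log units; within the scatter), the corresponding step from compound 2 is expected to be small, a step that the limit leaves unreadable from compound 2 to compound 4, with compound 2 itself at the limit. Compound 4 is therefore estimated at 40000 nM, most likely again reported only as a limit, within 15000 nM to 100000 nM.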

Compound 4, half-maximal inhibitory concentration: > 30000 nM
Compound 4 ended at the assay's limit (the forecaster's own chance of this, stated with the estimate: 70%); the middle value is on the limit's open side.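

In this assay compound 4 gives > 30000 nM as a limit and not a number. Within the data shown here, compound 2 stands at the same limit, so no step from compound 2 to compound 4 can be read: the limit of > 30000 nM in this assay, at which 2 of the 4 values shown sit. The compounds shown leave open how far past the limit each of the two lies, and whether fluoro in place of methoxy matters on this core.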